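The source may hold more compounds than are shown below. What is called first, only, known or untested is meant among the compounds shown, and "the series" means these compounds.

Three compounds built on a shared core were tested in a functional assay on T98G cells (Homo sapiens) for cytotoxicity, read by MTT assay, with a stated time of 48 h; on this read-out lower numbers stand for stronger inhibition and higher numbers for weaker inhibition. Compound 1 `C/C(=N/NC(=S)Nc1ccccc1I)c1ccccn1` gives 8.09 nM. Compound 3 `CC(=NNC(=S)Nc1ccc(Cl)cc1)c1ccccn1` gives 5.9 nM in this assay, a number within the scatter of that of compound 1. Compound 2 `C/C(=N\NC(=S)Nc1cccc(I)c1)c1ccccn1` gives 61 nM, the highest of the three and beyond the scatter from compound 1. Compound 1 thus stands second highest of the three, close to compound 3 and well apart from compound 2. Compound 4 `C/C(=N/NC(=S)Nc1ccccc1F)c1ccccn1` differs from compound 1 in one place: fluoro in place of iodo on an aromatic carbon. Among the measured compounds shown here, no measured pair shows this change, so its effect is unknown here. A modest step in this assay is expected, estimated as a 1.9-fold higher number from compound 1 to compound 4 (0.27 log units; within the scatter), toward a somewhat higher number that may still fall within the scatter. Compound 4 is therefore expected to give about 15 nM, within the range 5 nM to 45 nM.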

Compound 4, half-maximal inhibitory concentration: 3.1 nM
Beside the measured number, compound 4's estimate is 4.8-fold (0.68 log units) above it; measured number below the stated range.
By their numbers in this assay, from the lowest: compounds 4, 3 and 1 (each within the scatter of the next, the first and the last beyond it); then compound 2.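

Among the compounds shown here, putting fluoro in place of iodo on this aromatic carbon gives a 2.6-fold lower number from compound 1 to compound 4 (0.42 log units; beyond the scatter) in this assay and is the first single change that can be read. The step is modest but beyond the scatter, so iodo is not needed here for a low number, and the number is sensitive to the group at this place. No evidence at hand explains the direction of this step.

As far as these compounds go, how other groups at this place, such as methoxy or an amine, would compare remains open. So does whether the same swap would act alike elsewhere on this ring.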